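The compounds below may be only part of what the source reports. "The series", "measured", "known", "first", "only" and "open" are said of these compounds alone.

Among the measured compounds shown here, in a functional assay on SEM cells (Homo sapiens) for cytotoxicity, with a stated time of 72 h (on this read-out higher numbers stand for an effect only at larger amounts of compound and lower numbers for an effect already at smaller amounts), compound 1 `COc1ccc(/C=C/[C@@](C)(/C=C/c2ccc(O)c(C=O)c2)CCC=C(C)C)cc1` gives 4550 nM and compound 2 `COc1ccc(/C=C/[C@@](C)(/C=C/c2ccc(O)c(/C=C/C#N)c2)CCC=C(C)C)cc1` gives 4540 nM, so compound 2 stands level with the only other measured compound. The next compound is compound 3 `COc1ccc(/C=C/[C@@](C)(/C=C/c2ccc(O)c(/C=C/C(=O)OCc3ccccc3)c2)CCC=C(C)C)cc1`, with this change: benzyloxycarbonyl in place of cyano on a double-bonded chain carbon bound to a double-bonded chain carbon. In words, this is benzyloxycarbonyl in place of cyano on a double-bonded chain carbon bound to a double-bonded chain carbon. For the measured compounds named here, one measured step bears on it, a 1.0-fold lower number from compound 1 to compound 2 (0.00 log units; within the scatter), which exchanged formyl for 2-cyanoethenyl at the same aromatic carbon and stayed within the scatter. Going by the values given here, no measured compound carries a benzyloxycarbonyl group, so this single flat step is only a weak guide and the range is kept wide. In this assay, the expected change is a 1.1-fold lower number from compound 2 to compound 3 (0.05 log units; within the scatter), with no shift beyond the scatter anticipated. Compound 3 is estimated at 4000 nM, with an expected range of 1500 nM to 10000 nM.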

Compound 3, half-maximal effective concentration: > 36600 nM
Compound 3: a limit, no number; the forecaster's own chance of this, stated with the estimate: 10%; middle value at least 9.1-fold (0.96 log units) away from the limit.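

In this assay compound 3 carries a limit and not a number: the limit of > 36600 nM in this assay, at which 1 of the 3 values shown sits. Among the compounds shown here, the place on a double-bonded chain carbon bound to a double-bonded chain carbon is thus not indifferent to what it carries: benzyloxycarbonyl in place of cyano gives an at least 8.0-fold higher number from compound 2 to compound 3 (0.90 log units; beyond the scatter), whereas the only earlier step, a 1.0-fold lower number from compound 1 to compound 2 (0.00 log units; within the scatter), was flat. Set against formyl on the aromatic carbon, 2-(benzyloxycarbonyl)ethenyl gives an at least 8.0-fold higher number from compound 1 to compound 3 (0.90 log units; beyond the scatter), so the flat result holds for formyl and 2-cyanoethenyl only.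

As far as these compounds go, whether the shift comes with the benzyl part or with the carbonyl-bearing link itself stays open; a carboxylic acid or a methyl ester at the same place would separate the two. From the compounds shown here alone, how far compound 3 lies beyond its limit also stays open.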